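Adding pyridin-3-yl to a rapidly cleared compound

A few compounds are considered here, and "the series" means these few. Any claim that something is new, unique, unknown or untested is made for them only; others in the source may bear on it.

Compound 1 `COc1ccc2[nH]c(COc3cccc(OCC4CCOCC4)c3)c(C)c(=O)c2c1` gives "not determined" (no result reported)
Compound 2 `Cc1c(COc2cccc(OCC3CCOCC3)c2)[nH]c2ccccc2c1=O` gives 420 mL/min/kg

Going by the values given here, the measurement followed here is an in vitro ADME assay on microsomes from liver (Mus musculus) for metabolic stability, tested at 0.2 uM (on this read-out lower numbers stand for slow clearance and higher numbers for fast clearance), and only one of the two compounds has a number in it. With compound 2 at 420 mL/min/kg as the sole figure, there is nothing to rank it against, since compound 1 has no reported result.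

Compound 3 (`Cc1c(COc2cccc(OCC3CCOCC3)c2)[nH]c2ccc(-c3cccnc3)cc2c1=O`) differs from compound 2 in one place (pyridin-3-yl in place of hydrogen on an aromatic carbon): pyridin-3-yl in place of hydrogen on an aromatic carbon. Among the compounds with values here, no pair of measured compounds shows what a change like this does, so any expectation here is tentative. Compound 2, at 420 mL/min/kg on a scale where higher means faster clearance, leaves more room to fall than to rise, so a moderate fall is expected. The expected change is a 2.2-fold lower number from compound 2 to compound 3 (0.34 log units; beyond the scatter) and a result with no real change would not be surprising. The estimate for compound 3 is 190 mL/min/kg within an expected range of 70 mL/min/kg to 500 mL/min/kg for a single measurement.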

Compound 3, clearance: > 1000 mL/min/kg
Compound 3: no number, only a limit; the forecaster's own chance of this, stated with the estimate: 5%; middle value at least 5.2-fold (0.72 log units) from the limit.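

This step gives the first readable effect of a change on this aromatic carbon, which is meta to a fused ring and para to a fused ring: adding pyridin-3-yl in place of hydrogen produces an at least 2.3-fold higher number from compound 2 to compound 3 (0.37 log units; beyond the scatter), so on this read-out clearance rises rather than falls. In this assay, compound 3 gives > 1000 mL/min/kg, which is a limit of the assay and not a number. The true size of the rise therefore stays unknown, and the step gives only its smallest possible size, with the result sitting at the top of the range that can be read: the limit of > 1000 mL/min/kg in this assay, at which 1 of the 3 values shown sits.

Going by these compounds alone, compound 1 has no result, so no step involving it can be read, and the single step here cannot show whether the pyridine nitrogen matters or whether the added ring alone is enough to produce the rise. On these data alone, it also remains open whether a phenyl ring, a carboxylic acid or an aminomethyl group on this same aromatic carbon would raise clearance as well, or would bring it below the value of compound 2.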